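Triazole series: methoxy for trifluoromethyl, cytotoxicity notes

A few compounds are considered here, and "the series" means these few. Any claim that something is new, unique, unknown or untested is made for them only; others in the source may bear on it.

Measured so far in a functional assay on PC-12 cells (Rattus norvegicus) for cytotoxicity, read by MTT assay, with stated times of 2 h and 24 h, tested at 1 uM; a lower number here means a weaker effect, a higher number a stronger effect of the compound at the concentration tested:
compound 1 `Oc1cc(C(F)(F)F)ccc1-c1nc(-c2ccccc2O)n(-c2ccc(C(F)(F)F)cc2)n1` gives 70.7%
compound 2 `COc1ccc(-n2nc(-c3ccc(C(F)(F)F)cc3O)nc2-c2ccccc2O)cc1` gives 69%
compound 3 `Oc1cc(C(F)(F)F)ccc1-c1nc(-c2ccccc2O)n(-c2cccc(C(F)(F)F)c2)n1` gives 71.5%

The three differ only in the ring on the aromatic nitrogen. Compound 1 and compound 2 differ by methoxy in place of trifluoromethyl on an aromatic carbon, and this step is a number 1.7 percentage points lower from compound 1 to compound 2 (within the scatter). Compound 1 and compound 3 have the same atoms, joined differently: 3-(trifluoromethyl)phenyl in place of 4-(trifluoromethyl)phenyl on an aromatic nitrogen, with the step of a number 0.8 percentage points higher from compound 1 to compound 3 (within the scatter). Between compound 2 and compound 3 the step is a number 2.5 percentage points higher from compound 2 to compound 3 (within the scatter). All three numbers in this assay sit within the scatter of one another, so no order among them is claimed.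

Compound 4 `COc1cccc(-n2nc(-c3ccc(C(F)(F)F)cc3O)nc2-c2ccccc2O)c1` is not yet measured. It differs from compound 3 by methoxy in place of trifluoromethyl on an aromatic carbon. This is the same kind of change as that from compound 1 to compound 2, but not the same: there the methoxy stands para to a large group, here it stands meta to a large group. Among the compounds shown the change occurs two times in all. Among the compounds with values here, the one measured instance was within the scatter, and with only that to rest on the step from compound 3 to compound 4 in this assay is expected to be a number 1.5 percentage points lower from compound 3 to compound 4 (within the scatter), close to the earlier one. Compound 4 is therefore estimated at 70% in this assay, with an expected range from 62% to 78%.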

Compound 4, a percentage reported as activity, at one concentration (the size of the read-out at that concentration, not a potency): 68.3%
The estimate for compound 4 lay 1.7 percentage points above the measured number, within the range that was stated.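

In this assay the change of methoxy in place of trifluoromethyl on an aromatic carbon has now been seen on two cores, and the two steps do not differ: the same change on two cores in this assay, a number 1.7 percentage points lower (within the scatter) from compound 1 to compound 2 and a number 3.2 percentage points lower (within the scatter) from compound 3 to compound 4, 1.5 percentage points apart, within the scatter of two such steps The new compound adds nothing that separates the series, with the step of a number 3.2 percentage points lower from compound 3 to compound 4 (within the scatter), alongside a number 0.7 percentage points lower from compound 2 to compound 4 (within the scatter) and a number 2.4 percentage points lower from compound 1 to compound 4 (within the scatter), so no order among the four compounds is claimed. This shows that, across these two cores, the change carries over without a step beyond the scatter in this read-out at one concentration, but it does not show that the change has any real effect here, nor that the same would hold on a core outside these compounds or in a measure of potency.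

On these data alone, all four compounds share the two hydroxy-bearing rings and the trifluoromethyl on one of them, and the ring on the aromatic nitrogen carries only trifluoromethyl or methoxy, so it remains open whether an amine, a carboxylic acid or a longer alkoxy chain on that ring would move the number beyond the scatter. Also open, as far as these compounds go, is what happens to the number when either hydroxy group is replaced, for example by methoxy.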